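The compounds below may be only part of what the source reports. "The series", "measured", "known", "first", "only" and "open" are said of these compounds alone.

Measured compounds in a functional assay on A-375 cells (Homo sapiens) for antiproliferative activity, read by CCK-8 assay, with a stated time of 72 h, tested at 8 uM; a higher number here means a stronger effect of the compound at the concentration tested, a lower number a weaker effect:
- compound 1 `Nc1ccccc1NC(=O)c1ccc(CSC(=S)N2CCCc3ccccc32)cc1` gives 81.5%
- compound 2 `CN1CCN(C(=S)SCc2ccc(C(=O)Nc3ccccc3N)cc2)CC1` gives 91.6%

Compound 2 stands highest of the two numbers in this assay; its nearest neighbour is compound 1, and the step of a number 10.1 percentage points higher from compound 1 to compound 2 (beyond the scatter) lies beyond the scatter, though it is modest in size.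

Compound 3 `CN(Cc1ccncc1)C(=S)SCc1ccc(C(=O)Nc2ccccc2N)cc1` is not yet measured. It differs from compound 2 at the thiocarbonyl carbon: methyl((pyridin-4-yl)methyl)amino in place of 4-methylpiperazin-1-yl on a thiocarbonyl carbon

Among the compounds with values here, only one measured step bears on this change, a number 10.1 percentage points higher from compound 1 to compound 2 (beyond the scatter), and it concerns a different exchange at the same thiocarbonyl carbon, from one ring amine to another. It shows that this position tolerates variation with only a modest shift in this assay. Within the data shown here, no measured pair covers an open-chain amine at this place. The expected step of a number 6.6 percentage points lower from compound 2 to compound 3 (within the scatter) is therefore small, and likely not beyond the scatter. For compound 3 the estimated value in this assay is 85%, with a range from 70% to 95%.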

Compound 3, a percentage reported as inhibition, at one concentration (the size of the read-out at that concentration, not a potency): 86.1%
Compound 3: the middle estimate sits 1.1 percentage points below what was measured, within the range that was stated.
By their numbers in this assay, from the lowest: compounds 1, 3 and 2 (each within the scatter of the next, the first and the last beyond it).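

The open-chain methyl((pyridin-4-yl)methyl)amino group on the thiocarbonyl carbon gives a number 5.5 percentage points lower from compound 2 to compound 3 (within the scatter) against 4-methylpiperazin-1-yl and a number 4.6 percentage points higher from compound 1 to compound 3 (within the scatter) against 1,2,3,4-tetrahydroquinolin-1-yl in this assay and so stays within the scatter of both ring amines. Among these three compounds, a ring amine is therefore not required at this position for a read-out in this range, and compound 3 cannot be separated from compound 1 or compound 2, although those two stand apart. No available measurement accounts for these steps.

On these data alone, whether a morpholin-4-yl or dimethylamino group on the thiocarbonyl carbon, or a longer chain to the pyridine ring, would stay in this range remains open. Read at a single concentration, these values also leave potency open.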